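The source may hold more compounds than are shown below. What is called first, only, known or untested is meant among the compounds shown, and "the series" means these compounds.

Compound 1, `Cc1ccc2[nH]c(=O)c(CN(Cc3ccc(O)cc3)Cc3ccc(C(C)(C)C)cc3)cc2c1`, gives 4900 nM in a toxicity assay on MDCK cells (Canis lupus familiaris) for cytotoxicity, read by crystal violet staining, with a stated time of 48 h; a lower number here means that less compound is tolerated, a higher number that more compound is tolerated.
Compound 2, `Cc1ccc2[nH]c(=O)c(CN(Cc3ccc(SC(F)(F)F)cc3)Cc3ccc(C(C)(C)C)cc3)cc2c1`, gives > 5000 nM in this assay, which is a limit of the assay and not a number.

Among the compounds with values here, the only measured step, an at least 1.0-fold higher number from compound 1 to compound 2 (0.00 log units; that floor lies within the scatter), is an exchange on an aromatic carbon, and it carried the value only as far as the limit; compound 2 sits at that limit, (the limit of > 5000 nM in this assay, at which 1 of the 2 values shown sits), so where it truly stands is unknown. Compound 3, `COc1ccc(C(C)N(Cc2ccc(C(C)(C)C)cc2)Cc2cc3cc(C)ccc3[nH]c2=O)cc1Cl`, differs from compound 2 on the amine nitrogen: 1-(3-chloro-4-methoxyphenyl)ethyl in place of 4-((trifluoromethyl)sulfanyl)benzyl on an amine nitrogen. Within the data shown here, no measured step involves a change on this nitrogen, so the single step available is only a rough guide; it shows a change of one aromatic group leaving the value at the limit. The step of a number no higher from compound 2 to compound 3 (the limit leaves the size open) is therefore expected to be none beyond the scatter. The estimate for compound 3 is 5000 nM, within a range from 2500 nM to 10000 nM.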

Compound 3, half-maximal cytotoxic concentration: > 10000 nM
Compound 3 gave a limit, no number; the forecaster's own chance of this, stated with the estimate: 55%; at least 2.0-fold (0.30 log units) between middle value and limit.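

Compound 3 is the first compound shown with a change at the amine nitrogen, and its result is a limit of the assay, not a number: the limit of > 10000 nM in this assay, at which 1 of the 3 values shown sits. Measured against the 4-hydroxybenzyl group on the same nitrogen, 1-(3-chloro-4-methoxyphenyl)ethyl gives an at least 2.0-fold higher number from compound 1 to compound 3 (0.30 log units; that floor lies within the scatter), so the swap shows no fall in the tolerated concentration. Compound 2 and compound 3 both end in limits, and the step joining them cannot be read, which leaves their two groups on this nitrogen unordered.

Going by these compounds, how far the true value of compound 3 lies past its limit stays open. So does whether a methyl, a carboxylic acid or a second amine on this nitrogen would lower the tolerated concentration beyond the usual scatter.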